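Chloro in Place of Cyano: From Compound 1 to Compound 4

A few compounds are considered here, and "the series" means these few. Any claim that something is new, unique, unknown or untested is made for them only; others in the source may bear on it.

Compound 1 `N#Cc1ccc(NC(=S)N/N=C/c2ccc3ccccc3n2)cc1` was tested in a functional assay on SGC-7901 cells (Homo sapiens) for antiproliferative activity, read by sulforhodamine B assay, with a stated time of 72 h (on this read-out higher numbers stand for weaker inhibition and lower numbers for stronger inhibition), where compound 1 gives 23700 nM. This is the highest of the two numbers reported; compound 2 `CN(C)C(=S)N/N=C/c1cnc2ccccc2n1` gives 170 nM in this assay, a gap well beyond the scatter. Compound 3 `NC(=S)N/N=C/c1nc2ccccc2s1` reached only the limit of > 100000 nM in this assay (the limit of > 100000 nM in this assay, at which 1 of the 3 values shown sits). Compound 4 `S=C(N/N=C/c1ccc2ccccc2n1)Nc1ccc(Cl)cc1` has not yet been measured in this assay. It differs from compound 1 by chloro in place of cyano on an aromatic carbon, placed para to a large group. Among the compounds with values here, no measured pair shares this change, so the expectation rests on the change alone. Compound 4 is expected to show a modest gain, a 2.0-fold lower number from compound 1 to compound 4 (0.30 log units; within the scatter), in this assay. The estimated value of compound 4 is 12000 nM, with a range from 3000 nM to 60000 nM.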

Compound 4, half-maximal inhibitory concentration: 87600 nM
Beside the measured number, compound 4's estimate is 7.3-fold (0.86 log units) below it; measured number above the stated range.
By their numbers in this assay, from the lowest: compound 2; then compound 1; then compound 4. At a limit, above all of these: compound 3.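

The 4-chlorophenyl group does not match the 4-cyanophenyl group here: in this assay the change gives a 3.7-fold higher number from compound 1 to compound 4 (0.57 log units; beyond the scatter), which means weaker inhibition. Within the data shown here, this shows for the first time that this position responds to a single substituent, as the earlier compounds offered no step that differed in one place. It remains one pair, and nothing measured here accounts for the loss.

As far as these compounds go, whether an amine or a carboxylic acid at this position would give a lower number than the nitrile stays open. So does whether chloro in place of cyano would act alike on another core.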